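Notes on the step from compound 3 to compound 4

The source may hold more compounds than are shown below. What is called first, only, known or untested is meant among the compounds shown, and "the series" means these compounds.

Values in a functional assay on MCF7 cells (Homo sapiens) for antiproliferative activity, read by MTT assay, with a stated time of 48 h (on this read-out higher numbers stand for weaker inhibition and lower numbers for stronger inhibition), so far:
- compound 1 `Oc1ccc2ccccc2c1C(Nc1nc2ccc(Cl)cc2s1)c1cn(-c2ccccc2)nc1-c1ccc(F)cc1` gives 21600 nM
- compound 2 `O=[N+]([O-])c1cccc(-c2nn(-c3ccccc3)cc2C(Nc2nc3ccc(Cl)cc3s2)c2c(O)ccc3ccccc23)c1` gives 19700 nM
- compound 3 `COc1cccc(-c2nn(-c3ccccc3)cc2C(Nc2nc3ccc(Cl)cc3s2)c2c(O)ccc3ccccc23)c1` gives 36000 nM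

The value of compound 3 is not separated from the other two. The steps that place it are a 1.7-fold higher number from compound 1 to compound 3 (0.22 log units; within the scatter) and a 1.8-fold higher number from compound 2 to compound 3 (0.26 log units; within the scatter), and the remaining pair shows a 1.1-fold lower number from compound 1 to compound 2 (0.04 log units; within the scatter). All three lie within the scatter.

The unmeasured compound 4 `Oc1ccc2ccccc2c1C(Nc1nc2ccc(Cl)cc2s1)c1cn(-c2ccccc2)nc1-c1ccc(Cl)cc1` differs at one place: 4-chlorophenyl in place of 3-methoxyphenyl on an aromatic carbon. There, 4-chlorophenyl stands in place of 3-methoxyphenyl on an aromatic carbon of a five-membered aromatic ring with 2 nitrogen.

Within the data shown here, no measured compound carries 4-chlorophenyl. Among the measured compounds shown here, the closest precedent is the exchange of 4-fluorophenyl for 3-methoxyphenyl, seen in a 1.7-fold higher number from compound 1 to compound 3 (0.22 log units; within the scatter), and the present change runs the opposite way. The exchange of nitro for methoxy, seen in a 1.8-fold higher number from compound 2 to compound 3 (0.26 log units; within the scatter), is of similar size. Neither step gives grounds for a shift beyond the scatter in this assay, so none is expected. Any small drift would be expected toward the number of compound 1 at 21600 nM.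

The estimated move is a 1.6-fold lower number from compound 3 to compound 4 (0.19 log units; within the scatter), expected to stay within the scatter. For compound 4 the estimated value is 23000 nM, with an expected range from 10000 nM to 50000 nM.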

Compound 4, half-maximal inhibitory concentration: 27500 nM
Compound 4: the middle estimate sits 1.2-fold (0.08 log units) below what was measured; the measured number falls inside the stated range.
By their numbers in this assay, from the lowest: compounds 2, 1, 4 and 3 (each within the scatter of the next).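

At the aromatic carbon of the five-membered aromatic ring with 2 nitrogen, 4-chlorophenyl joins the aryl groups already seen in this assay, and it stands apart from none of them (a 1.3-fold lower number from compound 3 to compound 4 (0.12 log units; within the scatter); a 1.4-fold higher number from compound 2 to compound 4 (0.14 log units; within the scatter)). Among these compounds, the exchange of one halogen for another on this phenyl group, the only such exchange, also leaves the number unseparated (a 1.3-fold higher number from compound 1 to compound 4 (0.10 log units; within the scatter)), so all four aryl groups at this position now lie within the scatter of one another and none can be ranked ahead of another. No measurement is available that bears on why these values stay together.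

From the compounds shown here alone, whether a group of another kind at this carbon, such as an amine, a carboxylic acid or a longer alkyl chain, would move the number beyond the scatter remains open. Going by these compounds, all four compounds also share the rest of the core unchanged, so what the other parts of the structure contribute to the values in this assay also remains open.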